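Swapping iodo for methoxy in a growth inhibitor

The compounds below may be only part of what the source reports. "The series", "measured", "known", "first", "only" and "open" are said of these compounds alone.

Compound 1 `NC(=O)c1cc(Cl)ccc1NC(=O)COc1ccccc1` gives 10700 nM
Compound 2 `NC(=O)c1cc(I)ccc1NC(=O)COc1ccccc1` gives 1320 nM
Compound 3 `COc1ccc(NC(=O)COc2ccccc2)c(C(N)=O)c1` is not yet measured

Among the measured compounds shown here, in a functional assay on ACHN cells (Homo sapiens) for inhibition (on this read-out higher numbers stand for weaker inhibition of growth and lower numbers for stronger inhibition of growth), compound 2 stands at 1320 nM as the lower of the two numbers so far. Compound 3 differs from it by methoxy in place of iodo on an aromatic carbon and so carries methoxy in place of iodo on an aromatic carbon. For the measured compounds named here, the one measured step that bears on this is an 8.1-fold lower number from compound 1 to compound 2 (0.91 log units; beyond the scatter) and it put iodo in place of chloro, a modest change beyond the scatter. On these data alone, compound 3 has no iodo, so a move back toward compound 1 at 10700 nM is expected in this assay although methoxy itself is untested. The estimated step is a 3.8-fold higher number from compound 2 to compound 3 (0.58 log units; beyond the scatter) and it is of similar modest size. For compound 3 the expected value is 5000 nM with an estimated range of 1200 nM to 20000 nM in this read-out.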

Compound 3, concentration for 50% growth inhibition: 2250 nM
The estimate for compound 3 lay 2.2-fold (0.35 log units) above the measured number, within the range that was stated.
By their numbers in this assay, from the lowest: compounds 2 and 3 (each within the scatter of the next); then compound 1.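

In this assay, methoxy at this position, para to a large group, performs on a par with iodo: the record shows a 1.7-fold higher number from compound 2 to compound 3 (0.23 log units; within the scatter). Set against chloro, the picture is a 4.8-fold lower number from compound 1 to compound 3 (0.68 log units; beyond the scatter), so the lower number is not unique to iodo, since two quite different groups both stand clear of chloro. Nothing measured here offers a reason for this.

On these data alone, whether an amine or a carboxylic acid at this position would match compound 2 and compound 3 remains open. So does whether a longer chain, such as ethoxy, would keep that level.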